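Swapping a Cyanophenyl Ring for a Chlorothiophene Ring

A few compounds are considered here, and "the series" means these few. Any claim that something is new, unique, unknown or untested is made for them only; others in the source may bear on it.

Within the data shown here, the two compounds measured so far share one core and differ only in the aromatic group attached to it. Compound 1 `COc1ccccc1-n1nc(C2CC(C)(C)OC(C)(C)C2)cc1-c1ccnc(Cl)c1` carries a 2-chloropyridin-4-yl group, and in an assay on HEK293 cells for inhibition of Voltage-dependent N-type calcium channel subunit alpha-1B (Homo sapiens), read by patch clamp, using a membrane potential dye (a lower number here means a stronger inhibitor, a higher number a weaker inhibitor), compound 1 gives 740 nM. Compound 2 `COc1ccccc1-n1nc(C2CC(C)(C)OC(C)(C)C2)cc1-c1ccc(C#N)cc1` carries a 4-cyanophenyl group instead, and in this assay compound 2 gives 130 nM. That single exchange brought a 5.7-fold lower number from compound 1 to compound 2 (0.76 log units; beyond the scatter), so compound 2 stands as the lower of the two numbers, clearly separated from compound 1.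

Compound 3 `COc1ccccc1-n1nc(C2CC(C)(C)OC(C)(C)C2)cc1-c1csc(Cl)c1` has not yet been measured. Its difference from compound 2 is 5-chlorothiophen-3-yl in place of 4-cyanophenyl on an aromatic carbon. Among the measured compounds shown here, the only measured step that bears on this change is the one from compound 1 to compound 2, which lay beyond the scatter and favoured the 4-cyanophenyl group. Compound 3 brings back a chlorine-bearing heteroaromatic ring, as compound 1 had, so the number is expected to move back up, though a full return to the level of compound 1 is not assured. Compound 3 is therefore expected to shift by about a 2.7-fold higher number from compound 2 to compound 3 (0.43 log units; beyond the scatter). For compound 3 the estimated value in this assay is 350 nM, with a range from 120 nM to 1000 nM.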

Compound 3, half-maximal inhibitory concentration: 62 nM
Beside the measured number, compound 3's estimate is 5.6-fold (0.75 log units) above it; the measured number lies below the stated range.
By their numbers in this assay, from the lowest: compound 3; then compound 2; then compound 1.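

At this position on the shared core, 5-chlorothiophen-3-yl in place of 4-cyanophenyl brought a 2.1-fold lower number from compound 2 to compound 3 (0.32 log units; beyond the scatter) in this assay and so showed that a five-membered aromatic ring with one sulfur can outdo the best six-membered ring seen so far. Set against the 2-chloropyridin-4-yl group, the same ring gave a 12-fold lower number from compound 1 to compound 3 (1.08 log units; beyond the scatter) and this is the largest step among the three compounds, so a chlorine on the ring does not settle the number by itself: compound 1 and compound 3 both carry one, yet they stand at opposite ends of the series. Nothing available here accounts for these differences.

The compounds shown leave open whether the chlorine matters on the thiophene ring, a question that a bromine, a methyl group or a plain hydrogen in its place would answer. They also leave open how this position would respond to a ring bearing an amine or a carboxylic acid, and whether the gain holds when the 2-methoxyphenyl group changes.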